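The source may report more compounds than this note shows. Statements on the series, on what has been measured and on what is new or still open speak of the compounds shown alone.

The series is built on one shared core, present in compound 1 `CNC(=O)c1cc(Oc2ccc(C(=O)/C=C/c3ccco3)cc2)ccn1`, in compound 2 `CNC(=O)c1cc(Oc2ccc(C(=O)/C=C/c3cccc(Br)c3)cc2)ccn1` and in compound 3 `CNC(=O)c1cc(Oc2ccc(C(=O)/C=C/c3ccc(Br)cc3)cc2)ccn1`. The only read-out in hand is a functional assay on HepG2 cells (Homo sapiens) for cytotoxicity, read by MTT assay, with a stated time of 72 h; a higher number here means a weaker inhibitor, a lower number a stronger inhibitor. For compound 1 the entry there is "not determined" (no result reported), so it gives no point of comparison. Among the measured compounds shown here, compound 2 is therefore the single compound with a number: in this assay compound 2 gives 2870 nM, and it stands alone, with nothing measured to place it against.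

Compound 3 differs from compound 2 in one place: 4-bromophenyl in place of 3-bromophenyl on a double-bonded chain carbon bound to a double-bonded chain carbon. The two have the same atoms, joined differently, so the change is one of arrangement.

For the measured compounds named here, with no measured step of this kind available, the expected step in this assay is small, with no clear direction beyond the usual scatter of repeated measurements. The expectation is that the half-maximal inhibitory concentration of compound 3 stays close to that of compound 2, as the estimated step of a 1.1-fold lower number from compound 2 to compound 3 (0.06 log units; within the scatter) expresses. On that basis compound 3 is expected to give 2500 nM, within a range from 1000 nM to 7000 nM.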

Compound 3, half-maximal inhibitory concentration: > 50000 nM
Compound 3: only a limit was reported (the forecaster's own chance of this, stated with the estimate: 10%); middle value at least 20-fold (1.30 log units) away from the limit.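

In this assay, 4-bromophenyl in place of 3-bromophenyl on a double-bonded chain carbon bound to a double-bonded chain carbon gives an at least 17-fold higher number from compound 2 to compound 3 (1.24 log units; beyond the scatter), so this place on the shared core does not tolerate the two bromophenyl arrangements alike, even though the atoms are the same, something compound 2 alone could not show. For compound 3 the entry is a limit and not a number, > 50000 nM. The step therefore fixes only a minimum size, and how far compound 3 truly lies from compound 2 stays unknown: the limit of > 50000 nM in this assay, at which 1 of the 3 values shown sits.

The compounds shown leave open whether this sensitivity is tied to bromine itself, since only one pair can be read here and it says nothing of how 3-chlorophenyl and 4-chlorophenyl, or 3-methoxyphenyl and 4-methoxyphenyl, would compare in the same place. On these data alone, it is also open how an unsubstituted phenyl group would stand against compound 2 and compound 3, and compound 1, which has no number, offers no help on this.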